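Replacing a phenolic hydrogen with a heteroaromatic ring

A few compounds are considered here, and "the series" means these few. Any claim that something is new, unique, unknown or untested is made for them only; others in the source may bear on it.

Compound 1 `CCC(C)(C)Cc1c[nH]c(CCc2ccc(-c3ccccc3O)cc2)n1` gives 133 nM in a functional assay for agonist activity at Bombesin receptor subtype-3 (Homo sapiens) (a higher number here means that more compound is needed for the effect, a lower number that less compound is needed), the highest of the two numbers in hand. Its nearest measured neighbour, compound 2 `CCC(C)(C)Cc1c[nH]c(CCc2ccc(-c3ccccc3OCC(=O)O)cc2)n1`, gives 54 nM in this assay. Compound 3 `CCC(C)(C)Cc1c[nH]c(CCc2ccc(-c3ccccc3OCc3nc(=O)[nH][nH]3)cc2)n1` differs from compound 1 by a group of 7 heavy atoms (3 carbon, 3 nitrogen, 1 oxygen; one five-membered aromatic ring with 3 hetero atoms) in place of a hydrogen atom, on an oxygen on an aromatic ring. Among the compounds with values here, because a 2.5-fold lower number from compound 1 to compound 2 (0.39 log units; beyond the scatter) is the only change at this oxygen, and it lowered the number modestly, a lowering of similar size is expected for compound 3, a 2.2-fold lower number from compound 1 to compound 3 (0.35 log units; beyond the scatter). Compound 3 is therefore estimated at 60 nM, with a range from 25 nM to 150 nM.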

Compound 3, half-maximal effective concentration: 336 nM
Compound 3: middle estimate off by 5.6-fold (0.75 log units), on the low side; the whole stated range lies below it.
By their numbers in this assay, from the lowest: compound 2; then compound 1; then compound 3.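

In this assay, this oxygen does not answer in one direction when its hydrogen is replaced: the group with the five-membered aromatic ring gives a 2.5-fold higher number from compound 1 to compound 3 (0.40 log units; beyond the scatter), opposite in direction to the carboxymethyl step. Set directly against carboxymethyl, the same group gives a 6.2-fold higher number from compound 2 to compound 3 (0.79 log units; beyond the scatter), so the outcome depends on which group is attached and not merely on the hydrogen being replaced. No evidence at hand bears on this result.

The compounds shown leave open where a methyl ester or an amide of the carboxymethyl group, or a longer chain ending in a carboxylic acid, would fall in this assay.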